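The source may report more compounds than this note shows. Statements on the series, on what has been measured and on what is new or still open speak of the compounds shown alone.

Measured so far:
compound 1 `Nc1nc(O)c2c(n1)n(C1OC(CO)[C@@H](O)[C@H]1O)c(=O)n2CC(O)CO` — 45 uM
compound 2 `Nc1nc(O)c2c(n1)n(C1OC(CO)[C@@H](O)[C@H]1O)c(=O)n2Cc1ccc(Cl)cc1` — 14 uM

Both numbers come from a functional assay (B cells) with Mus musculus as the target; on this read-out lower numbers stand for an effect already at smaller amounts and higher numbers for an effect only at larger amounts of compound. Among the measured compounds shown here, compound 2 sits at the lower of the two numbers; its only neighbour is compound 1, and the step between them, a 3.2-fold lower number from compound 1 to compound 2 (0.51 log units; beyond the scatter), lies beyond the scatter. For the measured compounds named here, that step is the sole reference point for the series so far.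

Compound 3 `NC(=O)Cn1c(=O)n(C2OC(CO)[C@@H](O)[C@H]2O)c2nc(N)nc(O)c21` has not yet been measured. It differs from compound 2 by carbamoyl in place of 4-chlorophenyl on a saturated chain carbon bound to an aromatic nitrogen. Going by the values given here, the one measured step bears on this only loosely: there a six-membered aromatic ring of carbon only entered in place of a chain group on the same saturated chain carbon, and the number fell modestly. Here the ring leaves and a chain group enters, so the step is expected to run the other way, toward a higher number, with a size roughly comparable to a 3.2-fold lower number from compound 1 to compound 2 (0.51 log units; beyond the scatter), though the carbamoyl is not the 1,2-dihydroxyethyl of compound 1 and the match is imperfect.

In this assay compound 3 is therefore expected to give about 40 uM, within a range of 15 uM to 120 uM. The expected step is a 2.9-fold higher number from compound 2 to compound 3 (0.46 log units; beyond the scatter).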

Compound 3, concentration for half-maximal effect: 190 uM
Compound 3: the middle estimate sits 4.8-fold (0.68 log units) below what was measured, outside the stated range (above it).
By their numbers in this assay, from the lowest: compound 2; then compound 1; then compound 3.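

In this assay, among the compounds shown here, the saturated chain carbon bound to an aromatic nitrogen now shows a much wider spread than the first pair suggested, with carbamoyl in place of 4-chlorophenyl giving a 14-fold higher number from compound 2 to compound 3 (1.13 log units; beyond the scatter) and thus the largest step so far. The two groups without a ring are not interchangeable either: carbamoyl in place of 1,2-dihydroxyethyl gives a 4.2-fold higher number from compound 1 to compound 3 (0.63 log units; beyond the scatter) in the same direction, so loss of the six-membered aromatic ring does not by itself fix the number. For the compounds shown here, compound 3 now has the highest number of the three, with its steps to both others beyond the scatter, and compound 2, the only compound carrying a ring at this place, has the lowest. No measurement at hand offers an explanation for either step.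

From the compounds shown here alone, whether the low number of compound 2 goes with the ring or with the chlorine stays open, and a plain phenyl or a 4-methoxyphenyl at this place would help separate the two. Also open, going by these compounds, is how a carboxylic acid, an amine or a longer chain ending in carbamoyl would stand against compound 3.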